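A Methoxy Addition Weighed Against Three Inactive Limits

This account rests on a few compounds, and the source may have more. Where it says the series, first, only, none or still open, it means among the compounds named here.

Three compounds were tested in a functional assay on A549 cells (Homo sapiens) for cytotoxicity, read by MTT assay, with a stated time of 6 days; on this read-out lower numbers stand for an effect already at smaller amounts and higher numbers for an effect only at larger amounts of compound. Compound 1, `COc1cc(-c2oc3ccccc3c(=O)c2C(=O)O)cc(OC)c1OC`, gives in this assay only a limit of > 25 ug/mL. Compound 2, `COc1cc(OC)cc(-c2oc3ccccc3c(=O)c2C(=O)O)c1`, likewise reaches only a limit of > 25 ug/mL. Compound 3, `O=C(O)c1c(-c2ccc([N+](=O)[O-])cc2)oc2ccccc2c1=O`, also stops at a limit of > 25 ug/mL. The change from compound 2 to compound 1 is methoxy in place of hydrogen on an aromatic carbon, and the step it made, a step that the two limits leave unreadable from compound 2 to compound 1, cannot be sized since both ends are limits. How the core of compound 3 differs from that of compound 2 is not broken down here.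

Compound 4, `COc1ccc2c(=O)c(C(=O)O)c(-c3ccc([N+](=O)[O-])cc3)oc2c1`, has not yet been measured. It differs from compound 3 by methoxy in place of hydrogen on an aromatic carbon. This is the same kind of change as from compound 2 to compound 1, but the surroundings differ: in compound 1 the methoxy enters on a six-membered aromatic ring of carbon only, ortho to two methoxy groups and para to a large group, whereas in compound 4 it enters on such a ring that is part of a fused or bridged system of two rings, meta to a fused ring and para to a fused ring. The earlier step shows only that both of its ends sit at the limit. Given that (the limit of > 25 ug/mL in this assay, at which 3 of the 3 values shown sit), compound 4 is expected in this assay to remain at or near that limit too. The step this expectation implies is a step that the limit leaves unreadable from compound 3 to compound 4. Compound 4 is estimated at 30 ug/mL, within a range from 12 ug/mL to 80 ug/mL.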

Compound 4, concentration for half-maximal effect: > 25 ug/mL
Compound 4: no number, only a limit; the forecaster's own chance of this, stated with the estimate: 70%; the middle value does not contradict the limit.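

Compound 3 and compound 4 are both known in this assay only as limits, so no step can be read for methoxy in place of hydrogen on an aromatic carbon. All the compounds shown stand at the same place: the limit of > 25 ug/mL in this assay, at which 4 of the 4 values shown sit.

The compounds shown leave open what number any of them would reach in this assay, and so whether this methoxy change alters the read-out at all.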